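A few compounds are considered here, and "the series" means these few. Any claim that something is new, unique, unknown or untested is made for them only; others in the source may bear on it.

Working notes on the series

The set rests on one read-out, a functional assay on A549 cells (Homo sapiens) for antiproliferative activity, read by sulforhodamine B assay, with a stated time of 48 h; on this read-out higher numbers stand for weaker inhibition and lower numbers for stronger inhibition. Compound 1 `COc1cc(OC)c2sc(-c3ccc(N/C=C\C(=O)c4cc(OC)c(OC)c(OC)c4)cc3)nc2c1` gives 21800 nM in this assay. Compound 3 `COc1cc(C(=O)/C=C\Nc2ccc(-c3nc4cc(OC)c(OC)c(OC)c4s3)cc2C)cc(OC)c1OC` gives 23300 nM, and compound 2 `COc1cc(C(=O)/C=C\Nc2ccc(-c3nc4cc(OC)c(OC)c(OC)c4s3)cc2C)c(Br)c(OC)c1OC` gives 10300 nM. The value of compound 1 and the value of compound 3 sit within the scatter of each other, so no order between them is claimed. How the core of compound 1 and the core of compound 3 differ is not broken down here.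

Compound 2 arises from compound 3 by one change, (bromo in place of hydrogen on an aromatic carbon), which gave a 2.3-fold lower number from compound 3 to compound 2 (0.35 log units; beyond the scatter). Compound 4 `COc1cc(OC)c2sc(-c3ccc(N/C=C\C(=O)c4cc(OC)c(OC)c(OC)c4Br)cc3)nc2c1` is not yet measured; it arises from compound 1 by bromo in place of hydrogen on an aromatic carbon, and the surroundings of the changed carbon, as described for both pairs, are the same, so it is the same change on a different core.

Within the data shown here, because the same change gave a 2.3-fold lower number from compound 3 to compound 2 (0.35 log units; beyond the scatter), a step of similar size is expected on the core of compound 1; with only one earlier example, and the cores not broken down, this is held loosely. The expected step from compound 1 to compound 4 is estimated at a 2.3-fold lower number from compound 1 to compound 4 (0.36 log units; beyond the scatter) in this assay. Compound 4 is estimated at 9500 nM in this assay, with an expected range from 4500 nM to 19000 nM.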

Compound 4, half-maximal inhibitory concentration: 12000 nM
The estimate for compound 4 lay 1.3-fold (0.10 log units) below the measured number; low and high end bracket the measured number.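

In this assay, bromo in place of hydrogen on the aromatic carbon of the core of compound 1 gives a 1.8-fold lower number from compound 1 to compound 4 (0.26 log units; within the scatter), a step that taken alone cannot be told apart from the scatter of repeated measurements. Set beside the earlier example, the two steps do not differ, so the data fit one step of similar size on both cores: the same change on two cores in this assay, a 2.3-fold lower number (0.35 log units; beyond the scatter) from compound 3 to compound 2 and a 1.8-fold lower number (0.26 log units; within the scatter) from compound 1 to compound 4, 1.2-fold (0.10 log units) apart, within the scatter of two such steps

This supports carrying the bromo change from one core to the other in this series, but only as agreement between two pairs in a single assay; it does not establish a general rule, does not show a clear effect on the core of compound 1 by itself, and does not say why the step arises.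

The compounds shown leave open whether chloro, methyl or an amine on the same aromatic carbon would give a step of like size, and whether bromo on a different carbon of that ring would match it. Also open, on these data alone, is whether the step would survive on a core carrying a carboxylic acid or a longer chain in place of a methoxy group.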